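The source may hold more compounds than are shown below. What is called first, only, known or untested is meant among the compounds shown, and "the series" means these compounds.

Three compounds with a shared core and a long chain on it have been tested in a functional assay on MCF7 cells (Homo sapiens) for antiproliferative activity, read by MTT assay; a higher number here means a weaker inhibitor, a lower number a stronger inhibitor. Compound 3 `CCCCCCCCCCCCCCCc1cc(=O)c2c(O)c(C)c(O)cc2o1` carries an octyl at the end of its chain, and in this assay compound 3 gives 43200 nM. Compound 1 `CC/C=C\C/C=C\C/C=C\CCCCCCCc1cc(=O)c2c(O)c(C)c(O)cc2o1` shares the core of compound 3, and in this assay compound 1 gives 17500 nM. The change from compound 3 to compound 1 is a group of 10 heavy atoms (10 carbon; no ring) in place of a group of 8 heavy atoms (8 carbon; no ring), on a saturated chain carbon, seven bonds along the chain from an aromatic carbon, and it brought a 2.5-fold lower number from compound 3 to compound 1 (0.39 log units; beyond the scatter). Compound 2 `CCCCCCCCCCCCCCCc1cc(=O)c2c(O)cc(O)c(C)c2o1` has the same atoms as compound 3 joined differently; the difference between the two cores is not broken down here. In this assay compound 2 gives 17500 nM, level with compound 1 at the digits given and within the scatter of it, while its number is lower than that of compound 3 beyond the scatter.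

Compound 4 `CC/C=C\C/C=C\C/C=C\CCCCCCCc1cc(=O)c2c(O)cc(O)c(C)c2o1` is not yet measured. It stands to compound 2 as compound 1 stands to compound 3: the change is a group of 10 heavy atoms (10 carbon; no ring) in place of a group of 8 heavy atoms (8 carbon; no ring), on a saturated chain carbon, seven bonds along the chain from an aromatic carbon, the same change as from compound 3 to compound 1, at the same place on the chain. Going by the values given here, the single measured instance of that change, the step from compound 3 to compound 1, is the only ground for expectation here; whether it repeats on the core of compound 2 is unknown. The author expects a step of a 2.2-fold lower number from compound 2 to compound 4 (0.34 log units; beyond the scatter) in this assay for compound 4, resting on compound 1 and compound 3 and their step of a 2.5-fold lower number from compound 3 to compound 1 (0.39 log units; beyond the scatter). In this assay compound 4 is therefore estimated to give 8000 nM, expected to fall between 3500 nM and 18000 nM.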

Compound 4, half-maximal inhibitory concentration: 17500 nM
Estimate against measurement, compound 4: 2.2-fold (0.34 log units) below, within the range that was stated.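

Replacing the octyl with the group of 10 heavy atoms and 3 double bonds, on a saturated chain carbon, seven bonds along the chain from an aromatic carbon, gave in this assay no change at the digits printed from compound 2 to compound 4 (within the scatter), so the lower number seen on the first core did not reappear on the second. Set side by side, the two steps still cannot be told apart: the same change on two cores in this assay, a 2.5-fold lower number (0.39 log units; beyond the scatter) from compound 3 to compound 1 and no change at the digits printed (within the scatter) from compound 2 to compound 4, 2.5-fold (0.39 log units) apart, within the scatter of two such steps The series therefore does not show that the change carries from one core to the other, nor that it fails to, since each core offers a single pair and the gap between the two steps is no larger than repeated measurements could produce.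

The compounds shown leave open how a shorter or longer saturated chain, or a chain ending in a carboxylic acid or an amine, would read in this assay on either core. They also leave open whether a further pair of chains compared on both cores would give matching steps or would separate the two cores clearly.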